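The source may hold more compounds than are shown below. What is called first, only, known or untested is meant among the compounds shown, and "the series" means these compounds.

In a functional assay (trachea) with Cavia porcellus as the target (a higher number here means that more compound is needed for the effect, a lower number that less compound is needed), compound 1 `CCCn1c(=O)n(CCO)c(=O)c2[nH]cnc21` gives 510 nM and compound 2 `CCCn1c(=O)n(CCOC)c(=O)c2[nH]cnc21` gives 700 nM so the two stand within the scatter of each other. Compound 3 `CCCn1c(=O)n(CCCCC(C)=O)c(=O)c2[nH]cnc21` has 2-acetylethyl in place of methoxy on a saturated chain carbon, two bonds along the chain from an aromatic nitrogen, a difference from compound 2 counted as 2-acetylethyl in place of methoxy on a saturated chain carbon, two bonds along the chain from an aromatic nitrogen on the shared core. Going by the values given here, the one measured step of a 1.4-fold higher number from compound 1 to compound 2 (0.14 log units; within the scatter) altered the same chain and stayed small, but it does not cover a change of this kind. No shift beyond the scatter is therefore expected in this assay and the estimated step is a 1.6-fold lower number from compound 2 to compound 3 (0.19 log units; within the scatter) with a wide margin. For compound 3 the estimated value is 450 nM with a range from 130 nM to 1500 nM to allow for that gap.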

Compound 3, half-maximal effective concentration: 60 nM
The estimate for compound 3 lay 7.5-fold (0.88 log units) above the measured number, and the stated range ends above it.
By their numbers in this assay, from the lowest: compound 3; then compounds 1 and 2 (each within the scatter of the next).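

In this assay this position proves sensitive to the group it carries: 2-acetylethyl in place of methoxy gives a 12-fold lower number from compound 2 to compound 3 (1.07 log units; beyond the scatter), and 2-acetylethyl in place of hydroxy gives an 8.5-fold lower number from compound 1 to compound 3 (0.93 log units; beyond the scatter). The earlier change on this chain, on the oxygen, stayed within the scatter, so the small step gave no sign that a larger replacement could move the number this far. Nothing available explains the drop.

The added length and the carbonyl enter together, so their shares remain unseparated. A plain hexyl group in that place, or an amine at the chain end, would be needed to tell how much depends on the carbonyl.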